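The compounds below may be only part of what the source reports. "The series", "measured", "known", "first", "only" and "open" are said of these compounds alone.

In a functional assay on HeLa cells (Homo sapiens) for inhibition, read by MTT assay, with a stated time of 48 h (a lower number here means a stronger inhibitor, a higher number a weaker inhibitor), compound 1 `CCOC(=O)C1=C(N/C=N/c2cccnc2Cl)Nc2[nH]nc(C)c2C1c1ccc(N(C)C)cc1` gives 4630 nM, the lower of the two numbers measured, while compound 2 `CCOC(=O)C1=C(N/N=C(/C#N)C(=O)OCC)Nc2[nH]nc(C)c2C1c1ccc(N(C)C)cc1` gives 39200 nM. Compound 3 `CCOC(=O)C1=C(N/N=C(/C(=O)Br)c2ccc(Br)cc2)Nc2[nH]nc(C)c2C1c1ccc(N(C)C)cc1` differs from compound 1 by a group of 12 heavy atoms (8 carbon, 1 nitrogen, 1 oxygen, 2 bromine; one six-membered aromatic ring of carbon only) in place of a group of 9 heavy atoms (6 carbon, 2 nitrogen, 1 chlorine; one six-membered aromatic ring with 1 hetero atom), on an amine nitrogen. Among the compounds with values here, the one measured step at this amine nitrogen is an 8.5-fold higher number from compound 1 to compound 2 (0.93 log units; beyond the scatter), a modest change that leaves no ring in the new group, whereas compound 3 keeps a six-membered aromatic ring of carbon only. Within the data shown here, with only that step to go on, a smaller rise in the same direction is expected, a 2.6-fold higher number from compound 1 to compound 3 (0.41 log units; beyond the scatter). Compound 3 is therefore estimated at 12000 nM, with an expected range of 3500 nM to 40000 nM.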

Compound 3, half-maximal inhibitory concentration: 68500 nM
Beside the measured number, compound 3's estimate is 5.7-fold (0.76 log units) below it; the whole stated range lies below it.
By their numbers in this assay, from the lowest: compound 1; then compounds 2 and 3 (each within the scatter of the next).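

In this assay, a ring in the new group did not keep the number close to that of compound 1: a 15-fold higher number from compound 1 to compound 3 (1.17 log units; beyond the scatter), so the six-membered aromatic ring of carbon only on this amine nitrogen gave no advantage over the ring-free group. Nor does the ring separate the two replacement groups, with a 1.7-fold higher number from compound 2 to compound 3 (0.24 log units; within the scatter). No available evidence bears on why the group of compound 1 gives the lowest number of the three. The compounds shown leave open whether the chlorine of compound 1 matters. They also leave open how a pyridine ring without chlorine, or a simple amine, would read at this amine nitrogen.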